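The compounds below may be only part of what the source reports. "The series", "measured", "known", "first", "only" and "open" are said of these compounds alone.

Measured compounds in an ADME assay on MT4 cells (Homo sapiens) for cytotoxicity, read by MTT assay, with a stated time of 5 days; on this read-out higher numbers stand for lower toxicity in this test and lower numbers for higher toxicity in this test:
Compound 1 `O=[N+]([O-])c1ccc(-c2nnc(-c3cccnc3)n2Nc2nc3ccc(F)cc3s2)cc1` — >= 108 ug/mL
Compound 2 `O=[N+]([O-])c1ccc(-c2nnc(-c3cccnc3)n2Nc2nc3c([N+](=O)[O-])cccc3s2)cc1` — 13.8 ug/mL
Compound 3 `O=[N+]([O-])c1ccc(-c2nnc(-c3cccnc3)n2Nc2nc3c(Cl)cccc3s2)cc1` — 15.6 ug/mL

Compound 1 gives only a limit in this assay, (the limit of >= 108 ug/mL in this assay, at which 1 of the 3 values shown sits), so its value is not a number. Compound 2 and compound 3 both give numbers, and the step of a 1.1-fold higher number from compound 2 to compound 3 (0.05 log units; within the scatter) shows that the two sit within the scatter of each other; the change behind it is chloro in place of nitro on an aromatic carbon. The step of an at least 6.9-fold lower number from compound 1 to compound 3 (0.84 log units; beyond the scatter) is the only one here that reaches beyond the scatter, though it is anchored on a limit and so is known only as a lower bound. The difference between the core of compound 1 and the core of compound 2 is not broken down here.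

Compound 4 `Fc1ccc2nc(Nn3c(-c4ccc(Cl)cc4)nnc3-c3cccnc3)sc2c1` has not yet been measured. It differs from compound 1 by chloro in place of nitro on an aromatic carbon. For the measured compounds named here, this is the same kind of change as the one from compound 2 to compound 3, but not the same: in compound 4 it sits on a six-membered aromatic ring of carbon only, para to a large group, whereas from compound 2 to compound 3 it sits on a ring that is part of a fused system, ortho and meta to a fused ring.

Because the measured instance of this kind of change, a 1.1-fold higher number from compound 2 to compound 3 (0.05 log units; within the scatter), stayed within the scatter, compound 4 is expected to stay close to compound 1, with an estimated step of an at least 1.0-fold lower number from compound 1 to compound 4 (0.03 log units; that floor lies within the scatter) in this assay. Compound 4 is therefore estimated at 100 ug/mL in this assay, in the range 40 ug/mL to 200 ug/mL, and it may well come back as a limit again, as compound 1 did.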

Compound 4, half-maximal cytotoxic concentration: 92.9 ug/mL
Compound 4: the middle estimate sits 1.1-fold (0.03 log units) above what was measured; the range from low to high includes it.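

Taking 4-nitrophenyl to 4-chlorophenyl, on an aromatic carbon of a six-membered aromatic ring of carbon only, gives an at least 1.1-fold lower number from compound 1 to compound 4 (0.06 log units; that floor lies within the scatter) in this assay. From the compounds shown here alone, the value of compound 1, >= 108 ug/mL, is a limit of the assay and not a number, so this step is known only as a floor and its full size stays unknown. Chloro in place of nitro stayed within the scatter on one core, while on the other only the floor of the step did, so the two results are compatible with the change carrying over from core to core but do not establish that it does: the same change on two cores in this assay, a 1.1-fold higher number (0.05 log units; within the scatter) from compound 2 to compound 3 and an at least 1.1-fold lower number (0.06 log units; that floor lies within the scatter) from compound 1 to compound 4; the limit leaves it open whether they differ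

The compounds shown leave open whether an amine or a carboxylic acid in place of the chloro of compound 4, which gives 92.9 ug/mL, would also leave the number close to that value. They also leave open whether an at least 6.9-fold lower number from compound 1 to compound 3 (0.84 log units; beyond the scatter) would appear again with 4-chlorophenyl in place of 4-nitrophenyl, since all of the compounds with a chloro or nitro on the fused ring system carry the 4-nitrophenyl group.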